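A few compounds are considered here, and "the series" means these few. Any claim that something is new, unique, unknown or untested is made for them only; others in the source may bear on it.

Measured in a functional assay on MCF7 cells (Homo sapiens) for cytotoxicity, read by MTT assay, with a stated time of 48 h; on this read-out higher numbers stand for weaker inhibition and lower numbers for stronger inhibition:
- compound 1 `COc1cc(COCc2cn(Cc3cc(C)cnc3Cl)nn2)cc(OC)c1OC`: 67400 nM
- compound 2 `COc1cc(-c2cc(COCc3cn(Cc4cc(C)cnc4Cl)nn3)on2)cc(OC)c1OC`: 194000 nM
- compound 3 `COc1cc(C2=NOC(COCc3cn(Cc4cc(C)cnc4Cl)nn3)C2)cc(OC)c1OC`: 85500 nM

Compound 1 has the lowest of the three numbers at 67400 nM, but this does not set it apart from compound 3, which gives 85500 nM and lies within the scatter of it. Compound 2 gives 194000 nM, a higher number than compound 1 and beyond the scatter.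

The next compound is compound 4 `COc1cc(COCc2cn(Cc3cc(-c4ccccc4)cnc3Cl)nn2)cc(OC)c1OC`. It keeps the core of compound 1 but has phenyl in place of methyl on an aromatic carbon. This carbon sits on a six-membered aromatic ring with 1 nitrogen, two atoms from the ring nitrogen and para to a chloro group.

Among the measured compounds shown here, all three measured compounds carry methyl at this place, so no measured pair tests the change. The direction is therefore a weak expectation, and the wide range reflects this. In this assay, the expected change is a small one toward a lower number, a 1.6-fold lower number from compound 1 to compound 4 (0.21 log units; within the scatter), and it may not clear the scatter. For compound 4 the estimated value is 42000 nM, with an expected range of 14000 nM to 125000 nM.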

Compound 4, half-maximal inhibitory concentration: 86700 nM
Compound 4: middle estimate off by 2.1-fold (0.31 log units), on the low side; the range from low to high includes it.
By their numbers in this assay, from the lowest: compounds 1, 3 and 4 (each within the scatter of the next); then compound 2.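

In this assay the change at this place gives a 1.3-fold higher number from compound 1 to compound 4 (0.11 log units; within the scatter), a step within the scatter, so phenyl in place of methyl on this aromatic carbon, two atoms from the ring nitrogen and para to a chloro group, leaves no difference that this read-out can separate. Among the compounds shown here, this is the first measured test of the position, and it shows that, on the core of compound 1, the position carries the added six-membered aromatic ring of carbon only without a shift beyond repeated-measurement scatter. Nothing measured here offers a reason for this result.

Going by these compounds, whether an amine, a carboxylic acid or a longer alkyl chain at this place would move the number beyond the scatter remains open, as does the effect of a substituent on the phenyl itself. On these data alone, with a single step at this position, no trend can be drawn, and it is also open whether phenyl in place of methyl would read the same on the cores of compound 2 and compound 3.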